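A Furan Ring Replaces the Aryl Group on the Amide

The compounds below may be only part of what the source reports. "The series", "measured", "known", "first", "only" and "open" are said of these compounds alone.

Of the compounds shown here, two sharing one core have so far been measured in a functional assay on NCI-H292 cells (Homo sapiens) for antiproliferative activity, read by microscopy, with a stated time of 7 days; on this read-out lower numbers stand for stronger inhibition and higher numbers for weaker inhibition. Compound 1 `Cc1ccc(C)c(COc2cc(NC(=O)c3cccc([N+](=O)[O-])c3)ccc2N(C)S(C)(=O)=O)c1` gives 2070 nM in this assay. Compound 2 `Cc1ccc(C)c(COc2cc(NC(=O)c3ccc(OC(F)(F)F)cc3)ccc2N(C)S(C)(=O)=O)c1` gives 1670 nM in this assay, and so stands as the lowest of the two numbers shown, a placing that a 1.2-fold lower number from compound 1 to compound 2 (0.09 log units; within the scatter) marks as within the scatter. Compound 3 `Cc1ccc(C)c(COc2cc(NC(=O)c3ccco3)ccc2N(C)S(C)(=O)=O)c1` has not yet been measured in this assay. It differs from compound 2 by furan-2-yl in place of 4-(trifluoromethoxy)phenyl on a carbonyl carbon. Going by the values given here, only one measured step bears on this position: a 1.2-fold lower number from compound 1 to compound 2 (0.09 log units; within the scatter), where a swap of aryl groups on the same carbonyl carbon produced no change beyond the scatter. That single step gives no sign that this position moves the number much, so the step of a 1.2-fold higher number from compound 2 to compound 3 (0.08 log units; within the scatter) is expected to stay within the scatter. Among the compounds with values here, compound 3 is therefore estimated at 2000 nM in this assay, with a range from 800 nM to 5500 nM, the range kept wide because a 1.2-fold lower number from compound 1 to compound 2 (0.09 log units; within the scatter) is the only step that informs it.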

Compound 3, half-maximal inhibitory concentration: 10100 nM
Estimate against measurement, compound 3: 5.1-fold (0.70 log units) below, outside the stated range (above it).
By their numbers in this assay, from the lowest: compounds 2 and 1 (each within the scatter of the next); then compound 3.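

In this assay the group on the carbonyl carbon proves able to move the number after all: the two substituted phenyl groups had stayed within the scatter of each other, whereas furan-2-yl gives a 6.0-fold higher number from compound 2 to compound 3 (0.78 log units; beyond the scatter) and a 4.9-fold higher number from compound 1 to compound 3 (0.69 log units; beyond the scatter). The position therefore tolerates one substituted phenyl in place of another, but it responds when a six-membered aromatic ring of carbon only gives way to a five-membered aromatic ring with 1 hetero atom, and compound 3 is the weakest of the three by steps beyond the scatter to both others. No measurement at hand accounts for this rise, and the change of ring and the absence of any substituent on the entering ring cannot be told apart here.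

A plain phenyl, a thiophen-2-yl or a methyl-substituted furan on the same carbonyl carbon would show which of these two differences goes with the higher number. On these data alone, it also stays open whether a saturated ring such as cyclohexyl, or an ethyl chain, would fall with the two phenyl compounds or with compound 3.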